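The source may hold more compounds than are shown below. What is called first, only, known or untested is meant among the compounds shown, and "the series" means these compounds.

Measured compounds:
compound 1 `CC(C)n1nc(-c2cc(-c3ccccc3)on2)c2c(N)ncnc21` in an ADME assay on Nthy-ori 3-1 cells (Homo sapiens) for cytotoxicity, read by MTT assay, with a stated time of 10 days (on this read-out higher numbers stand for weaker inhibition of growth and lower numbers for stronger inhibition of growth), gives 5720 nM.
compound 2 `CC(C)n1nc(/C=N/OCc2ccccc2)c2c(N)ncnc21` in this assay gives 9850 nM.
compound 3 `Nc1ncnc2c1c(-c1cc(C3CC3)on1)nn2C1CCOCC1` in this assay gives 32900 nM.

Of the three numbers, compound 1 carries the lowest, yet compound 2 lies within the usual scatter of it, so the two cannot be told apart on this read-out. Compound 3 stands apart: its number is higher than that of compound 1 by a margin beyond the scatter, and its structure differs in more than one place, so nothing about any single change can be drawn from that pair.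

Compound 4 `CC(C)n1nc(-c2cc(-c3ccc(F)cc3)on2)c2c(N)ncnc21` has not been measured. It differs from compound 1 in one place: fluoro in place of hydrogen on an aromatic carbon. The change brings in a single heavy atom and leaves every other part of the molecule as it is. Among the measured compounds shown here, no measured pair shows a step of this kind. From the small size of the change and the closeness of compound 1 and compound 2, the step in this assay from compound 1 to compound 4 is expected to be none beyond the scatter, in either direction, as an estimated 1.0-fold lower number from compound 1 to compound 4 (0.02 log units; within the scatter). Compound 4 is therefore expected to give about 5500 nM, within a range of 2200 nM to 14000 nM.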

Compound 4, concentration for 50% growth inhibition: 9770 nM
Compound 4: middle estimate off by 1.8-fold (0.25 log units), on the low side; the range from low to high includes it.
By their numbers in this assay, from the lowest: compounds 1, 4 and 2 (each within the scatter of the next); then compound 3.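

In this assay, among the compounds shown here, the change from phenyl to 4-fluorophenyl gives a 1.7-fold higher number from compound 1 to compound 4 (0.23 log units; within the scatter), the only step here between compounds that differ in one place. For the compounds shown here, on an aromatic carbon para to a large group, fluoro in place of hydrogen therefore cannot be told apart from hydrogen on this read-out, something the earlier compounds, which all differ in more than one place, could not show. No measurement given here explains this result.

On these data alone, whether a different group at this same position, such as an amine, a carboxylic acid or a methoxy group, would give a step beyond the scatter remains open. Also open, as far as these compounds go, is whether fluoro on another carbon of that phenyl ring would read the same way.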